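The source may report more compounds than this note shows. Statements on the series, on what has been measured and on what is new or still open speak of the compounds shown alone.

Measured so far in a functional assay on HepG2 cells (Homo sapiens) for antiproliferative activity, read by MTT assay, with a stated time of 72 h; on this read-out lower numbers stand for stronger inhibition and higher numbers for weaker inhibition:
- compound 1 `C=CC(=O)Nc1cc(Nc2nccc(-c3cn(C)c4ccc(F)cc34)n2)c(OC)cc1N(C)CCN(C)C` — 429 nM
- compound 2 `CC/C=C\C(=O)Nc1cc(Nc2nccc(-c3cn(C)c4ccc(F)cc34)n2)c(OC)cc1N(C)CCN(C)C` — 5290 nM
- compound 3 `CCC/C=C\C(=O)Nc1cc(Nc2nccc(-c3cn(C)c4ccc(F)cc34)n2)c(OC)cc1N(C)CCN(C)C` — 3400 nM

Compound 1 gives the lowest number of the three, and both others lie beyond the scatter from it: a 12-fold higher number from compound 1 to compound 2 (1.09 log units; beyond the scatter) and a 7.9-fold higher number from compound 1 to compound 3 (0.90 log units; beyond the scatter). Those two steps replace the vinyl on the carbonyl carbon with longer chains, while the step between the longer chains, a 1.6-fold lower number from compound 2 to compound 3 (0.19 log units; within the scatter), stays within the scatter.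

Compound 4 `C=CC(=O)Nc1cc(Nc2ncc(C#N)c(-c3cn(C)c4ccc(F)cc34)n2)c(OC)cc1N(C)CCN(C)C` keeps the vinyl and the rest of compound 1 and differs only by cyano in place of hydrogen on an aromatic carbon. Within the data shown here, none of the measured steps touches this ring carbon; all of them alter the chain on the carbonyl carbon, so they offer no guide to what a cyano group at this position does. Without any step bearing on the change, the plain expectation is that compound 4 stays near compound 1, with a step of a 1.0-fold higher number from compound 1 to compound 4 (0.00 log units; within the scatter), and the estimate for compound 4 in this assay is 430 nM, expected to fall between 130 nM and 1400 nM.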

Compound 4, half-maximal inhibitory concentration: 17500 nM
Beside the measured number, compound 4's estimate is 41-fold (1.61 log units) below it; the whole stated range lies below it.
By their numbers in this assay, from the lowest: compound 1; then compounds 3 and 2 (each within the scatter of the next); then compound 4.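

In this assay, placing a cyano group on this aromatic carbon, ortho to the 5-fluoro-1-methyl-1H-indol-3-yl group, gives a 41-fold higher number from compound 1 to compound 4 (1.61 log units; beyond the scatter). This shows that the ring carbon is a sensitive site, even though the change adds only two heavy atoms. It also shows that keeping the vinyl on the carbonyl carbon is not enough to hold the low number of compound 1, and nothing measured here gives a reason for the rise.

Open, from the compounds shown here alone, is whether this rise is particular to cyano or would also follow from another group on the same carbon, such as a methyl, a chlorine or an amine. Also open, going by these compounds, is how cyano at this position would behave alongside the longer chains of compound 2 and compound 3.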